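Swapping the aryl substituent at the chain end

The source may hold more compounds than are shown below. What is called first, only, known or untested is meant among the compounds shown, and "the series" means these compounds.

Within the data shown here, the three compounds measured so far share one core and differ only in the aromatic group at the far end of the chain. Compound 1 `O=C(CCCCCCc1cccnc1)c1ncc(-c2ccccn2)o1` gives 32 nM in an assay for inhibition of Fatty-acid amide hydrolase 1 (Rattus norvegicus); on this read-out lower numbers stand for stronger inhibition and higher numbers for weaker inhibition. Compound 2 `COc1ccc(CCCCCCC(=O)c2ncc(-c3ccccn3)o2)cc1` gives 6.2 nM, the lowest number of the three. Compound 3 `Nc1cccc(CCCCCCC(=O)c2ncc(-c3ccccn3)o2)c1` gives 30 nM. The two steps that change this aromatic group are a 5.2-fold lower number from compound 1 to compound 2 (0.71 log units; beyond the scatter) and a 4.8-fold higher number from compound 2 to compound 3 (0.68 log units; beyond the scatter), both beyond the scatter, while a 1.1-fold lower number from compound 1 to compound 3 (0.03 log units; within the scatter) stays within it.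

Compound 4 `CC(C)(C)OC(=O)Nc1ccc(CCCCCCC(=O)c2ncc(-c3ccccn3)o2)cc1` differs from compound 2 in one place: (tert-butoxycarbonyl)amino in place of methoxy on an aromatic carbon, on an aromatic carbon of a six-membered aromatic ring of carbon only, para to a large group. The entering group is larger than the methoxy it replaces and carries a hydrogen-bond donor. The steps from compound 1 to compound 2 and from compound 2 to compound 3 bear on this change, as both move the same position and each shifted the number modestly, with compound 2 standing at the favourable end. A shift of similar size away from compound 2 is therefore expected for compound 4, a 3.2-fold higher number from compound 2 to compound 4 (0.51 log units; beyond the scatter). Compound 4 is estimated at 20 nM, with a likely range from 5 nM to 80 nM.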

Compound 4, inhibition constant: 5.6 nM
Estimate against measurement, compound 4: 3.6-fold (0.55 log units) above; the range from low to high includes it.
By their numbers in this assay, from the lowest: compounds 4 and 2 (each within the scatter of the next); then compounds 3 and 1 (each within the scatter of the next).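

In this assay, the step from methoxy to (tert-butoxycarbonyl)amino, a 1.1-fold lower number from compound 2 to compound 4 (0.04 log units; within the scatter), stays within the scatter, so this exchange leaves no readable change in the number. The earlier steps shown here replaced the whole aromatic group at the chain end, whereas this one keeps the six-membered aromatic ring of carbon only and changes just the group on it, para to a large group: 8 heavy atoms enter where 2 leave, and 1 hydrogen-bond donor enters where there were 0, yet the number holds, which shows that at this place, in this one pair, a much larger group with a donor can stand in for methoxy without a measurable cost. Nothing measured here explains why the number holds across this exchange.

On these data alone, one pair cannot show how far this holds, so it remains open whether a free amine or a carboxylic acid on the same aromatic carbon, both groups that could carry a net charge, would leave the number equally undisturbed. As far as these compounds go, it is also open whether the same exchange would give the same result on a shorter or a longer chain.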